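A few compounds are considered here, and "the series" means these few. Any claim that something is new, unique, unknown or untested is made for them only; others in the source may bear on it.

The account follows compound 1, `Cn1c(-c2ccccc2F)cnc1NC(=O)c1ccc(F)cc1`, which carries 2-fluorophenyl on the shared core. In a toxicity assay on THP-1 cells (Homo sapiens) for inhibition (a lower number here means that less compound is tolerated, a higher number that more compound is tolerated), compound 1 gives > 100000 nM, which is a limit of the assay and not a number. Two further compounds stand beside it. Compound 2, `COc1ccc(-c2cnc(NC(=O)C3CCCC3)n2C)cc1`, gives in this assay > 100000 nM, again a limit. Compound 3, `COc1ccc(-c2cnc(NC(=O)c3ccco3)n2C)cc1`, gives in this assay > 100000 nM, likewise a limit. Going by the values given here, the one step between measured compounds, a step that the two limits leave unreadable from compound 2 to compound 3, can therefore not be sized. All three values sit at the limit of > 100000 nM in this assay, at which 3 of the 3 values shown sit, so compound 1 stands exactly where everything shown stands, at the limit.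

Compound 4, `Cn1c(-c2ccc(Cl)cc2)cnc1NC(=O)c1ccc(F)cc1`, differs from compound 1 in one place: 4-chlorophenyl in place of 2-fluorophenyl on an aromatic carbon. Among the compounds with values here, no measured step bears on this change; the only measured step, a step that the two limits leave unreadable from compound 2 to compound 3, concerns a change on a carbonyl carbon in other compounds and is itself unreadable. Because every value shown sits at the limit of > 100000 nM in this assay, at which 3 of the 3 values shown sit, the step of a number no higher from compound 1 to compound 4 (the limit leaves the size open) is expected to be none beyond the scatter, with the value most likely once more at the limit. Compound 4 is thus expected to give 100000 nM in this assay, within a range from 50000 nM to 200000 nM.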

Compound 4, half-maximal cytotoxic concentration: 37000 nM
Estimate against measurement, compound 4: 2.7-fold (0.43 log units) above, and the stated range ends above it.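

Going by these compounds alone, the exchange of 2-fluorophenyl for 4-chlorophenyl, on this aromatic carbon of the shared core, gives an at least 2.7-fold lower number from compound 1 to compound 4 (0.43 log units; beyond the scatter), so a change at this place can move the read-out of this assay, which the earlier compounds could not show. Compound 1 gives > 100000 nM, which is a limit and not a number, so the step has a lower bound on its size and no exact value. In this assay, within the data shown here, compound 4 gives 37000 nM, the one number, with less compound tolerated than for compound 1. All other compounds shown remain at the limit: the limit of > 100000 nM in this assay, at which 3 of the 4 values shown sit.

The compounds shown leave open whether the chlorine or its place on the phenyl ring accounts for the step, since both differ at once between compound 1 and compound 4, and 4-fluorophenyl or 2-chlorophenyl at this carbon would separate the two. Among these compounds, they also leave open how an unsubstituted phenyl or a 4-bromophenyl would read here, and the one step on the carbonyl carbon, between two limits, stays unreadable.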